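A few compounds are considered here, and "the series" means these few. Any claim that something is new, unique, unknown or untested is made for them only; others in the source may bear on it.

Three compounds that share one core, each carrying a sulfonamide nitrogen in a ring, were tested in an ADME assay on HCT-116 cells (Homo sapiens) for cytotoxicity, read by CellTiter-Glo, with a stated time of 72 h; on this read-out lower numbers stand for stronger inhibition and higher numbers for weaker inhibition. Compound 1 `Cc1ccc(-c2ccccc2S(=O)(=O)N2CCC(N3CCC(C)CC3)CC2)cc1` gives > 5000 nM, which is a limit of the assay rather than a number. Compound 2 `Cc1ccc(S(=O)(=O)N2CCC(N3CCC(C)CC3)CC2)cc1C` gives > 5000 nM, again a limit. Compound 3 `Cc1cc(S(=O)(=O)N2CCC(N3CCC(C)CC3)CC2)c(Cl)cc1Cl` gives > 5000 nM, also a limit. Compound 2 therefore stands where every value shown stands, at the limit of > 5000 nM in this assay, at which 3 of the 3 values shown sit. Compound 4 `CC1CCN(C2CCN(S(=O)(=O)c3cncc(Br)c3)CC2)CC1` has not yet been measured; it differs from compound 2 by 5-bromopyridin-3-yl in place of 3,4-dimethylphenyl on a sulfonyl sulfur. For the measured compounds named here, no step between measured compounds is available, so the expected change from compound 2 to compound 4, a step that the limit leaves unreadable from compound 2 to compound 4, is none beyond the scatter. Compound 4 is expected to give about 8000 nM, between 3000 nM and 25000 nM, most likely reported again only as a limit.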

Compound 4, half-maximal inhibitory concentration: > 10000 nM
Compound 4: no number, only a limit; the forecaster's own chance of this, stated with the estimate: 85%; middle value at least 1.2-fold (0.09 log units) from the limit.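

For the compounds shown here, compound 2 and compound 4 are both reported only as limits, and no step from one to the other can be read. The compounds shown leave open whether any group on the sulfonyl sulfur would give a true number rather than a limit.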